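The compounds below may be only part of what the source reports. "The series", "measured", "known", "first", "only" and "open" are said of these compounds alone.

Measured so far in a physicochemical assay for lipophilicity, measured as octanol-water partition; on this read-out higher numbers stand for higher lipophilicity and lower numbers for lower lipophilicity:
- compound 1 `CC1=C(C(=O)OCc2cccnc2)C(c2ccc(C#N)cc2)C2=C(CCCC2=O)N1`: 1.36
- compound 2 `CC1=C(C(=O)OCc2ccccn2)C(c2ccc(C#N)cc2)C2=C(CCCC2=O)N1`: 1.73
- compound 3 `CC1=C(C(=O)OCc2ccccn2)C(c2ccc(O)cc2)C2=C(CCCC2=O)N1`: 1.58

Compound 1, at 1.36, lies within the usual scatter of compound 3 and beyond it from compound 2. Compound 4 `CC1=C(C(=O)OCc2cccnc2)C(c2cccs2)C2=C(CCCC2=O)N1` keeps the rest of compound 1 but has thiophen-2-yl in place of 4-cyanophenyl on a saturated ring carbon. Among the compounds with values here, the one measured step that touches the 4-cyanophenyl group is a number 0.15 log units lower from compound 2 to compound 3 (within the scatter). The other, a number 0.37 log units higher from compound 1 to compound 2 (beyond the scatter), concerns the pyridinyl group instead, so it bears on this change only weakly. Neither step involves thiophen-2-yl, so the guidance is indirect. A small change is expected, a number 0.19 log units higher from compound 1 to compound 4 (within the scatter), and it is not expected to stand clear of the scatter. For compound 4 the estimated value is 1.55, with an expected range of 1.15 to 1.95.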

Compound 4, partition coefficient: 1.4
Compound 4: the middle estimate sits 0.15 log units above what was measured; the measured number falls inside the stated range.
By their numbers in this assay, from the lowest: compounds 1, 4, 3 and 2 (each within the scatter of the next, the first and the last beyond it).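

On the saturated ring carbon, thiophen-2-yl in place of 4-cyanophenyl gives a number 0.04 log units higher from compound 1 to compound 4 (within the scatter) in this assay. Swapping a six-membered aromatic ring bearing a nitrile for a five-membered aromatic ring with sulfur therefore leaves this read-out within the scatter, the first such ring exchange seen at this position. Nothing measured here explains this result. As far as these compounds go, it remains open whether a non-ring group on this carbon, such as an amine or a carboxylic acid, would give a step beyond the scatter. Also open, from the compounds shown here alone, is how thiophen-2-yl behaves alongside pyridin-2-yl instead of pyridin-3-yl.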